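The source may report more compounds than this note shows. Statements on the series, on what has been measured and on what is new or still open speak of the compounds shown alone.

Within the data shown here, compound 2 `C=CC(=O)Nc1cc(Nc2nc(C)cc(-c3cn(C)c4ccc(F)cc34)n2)c(OC)cc1N(C)CCN(C)C` stands at the low end of the two numbers measured so far in a functional assay on NCI-H1975 cells (Homo sapiens) for antiproliferative activity, read by MTT assay, with a stated time of 72 h; a lower number here means a stronger inhibitor, a higher number a weaker inhibitor: compound 2 gives 3830 nM. Compound 1 `COc1cc(N(C)CCN(C)C)c(NC(=O)/C=C\C(C)C)cc1Nc1nccc(-c2cn(C)c3ccc(F)cc23)n1`, which differs from it in two places, gives 7360 nM in this assay, and the gap between the two lies within the usual scatter, so neither can be called the more potent. Compound 3 `COc1cc(N(C)CCN(C)C)c(NC(=O)/C=C\C(C)C)cc1Nc1nc(C)cc(-c2cn(C)c3ccc(F)cc23)n1` has not yet been measured. It arises from compound 2 by one change, (3-methylbut-1-en-1-yl in place of vinyl on a carbonyl carbon). Among the measured compounds shown here, no measured pair isolates this change, so the step is expected to be modest and toward a higher number, estimated at a 1.8-fold higher number from compound 2 to compound 3 (0.26 log units; within the scatter). Compound 3 is therefore expected to give about 7000 nM in this assay, within a range of 2500 nM to 20000 nM.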

Compound 3, half-maximal inhibitory concentration: 8520 nM
Beside the measured number, compound 3's estimate is 1.2-fold (0.09 log units) below it; the measured number falls inside the stated range.
By their numbers in this assay, from the lowest: compounds 2, 1 and 3 (each within the scatter of the next, the first and the last beyond it).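

In this assay, 3-methylbut-1-en-1-yl in place of vinyl on the carbonyl carbon gives a 2.2-fold higher number from compound 2 to compound 3 (0.35 log units; beyond the scatter), a modest loss of activity that lies just beyond the scatter. Methyl in place of hydrogen on an aromatic carbon gives a 1.2-fold higher number from compound 1 to compound 3 (0.06 log units; within the scatter), so with 3-methylbut-1-en-1-yl on the carbonyl, this methyl has no readable effect. Nothing measured here explains either step. Going by these compounds, it remains open how a chain carrying an amine would behave on that carbonyl carbon. On these data alone, it also remains open whether the methyl has any effect when vinyl sits there.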